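Pyrrolidine amide replaces cyclohexyl amide in a thiourea series

A few compounds are considered here, and "the series" means these few. Any claim that something is new, unique, unknown or untested is made for them only; others in the source may bear on it.

Compound 1 `O=C(c1cc(Oc2cccc(NC(=S)Nc3ccc(F)c(F)c3)c2)ccn1)N1CCCC1`: 45600 nM
Compound 2 `CCNC(=O)c1cc(Oc2cccc(NC(=S)Nc3cccc(C(F)(F)F)c3)c2)ccn1`: 18300 nM
Compound 3 `O=C(NC1CCCCC1)c1cc(Oc2cccc(NC(=S)Nc3cccc(C(F)(F)F)c3)c2)ccn1`: 16800 nM

In a functional assay on PC-3 cells (Homo sapiens) for cytotoxicity, read by MTT assay, with a stated time of 48 h (on this read-out higher numbers stand for weaker inhibition and lower numbers for stronger inhibition), compound 3 gives the lowest of the three numbers, though compound 2 lies close to it, and the change between them, a 1.1-fold lower number from compound 2 to compound 3 (0.04 log units; within the scatter), counts as no real difference. Compound 4 `O=C(c1cc(Oc2cccc(NC(=S)Nc3cccc(C(F)(F)F)c3)c2)ccn1)N1CCCC1` is not yet measured; it carries the change (pyrrolidin-1-yl in place of cyclohexylamino on a carbonyl carbon). Within the data shown here, the only measured step at this same position, a 1.1-fold lower number from compound 2 to compound 3 (0.04 log units; within the scatter), shows that swapping one amide substituent for another left the number essentially where it was. Among the measured compounds shown here, that step is the sole guide here, so for compound 4 no step beyond the scatter is expected, with a 1.2-fold higher number from compound 3 to compound 4 (0.08 log units; within the scatter). Compound 4 is therefore estimated at 20000 nM, within a range from 8000 nM to 50000 nM.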

Compound 4, half-maximal inhibitory concentration: 27000 nM
Beside the measured number, compound 4's estimate is 1.4-fold (0.13 log units) below it, within the range that was stated.
By their numbers in this assay, from the lowest: compounds 3, 2, 4 and 1 (each within the scatter of the next, the first and the last beyond it).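

Losing the amide hydrogen at this carbonyl carbon does not move the number beyond the scatter, whether pyrrolidin-1-yl replaces cyclohexylamino (a 1.6-fold higher number from compound 3 to compound 4 (0.21 log units; within the scatter)) or ethylamino (a 1.5-fold higher number from compound 2 to compound 4 (0.17 log units; within the scatter)). On the other side of the molecule, 3-(trifluoromethyl)phenyl in place of 3,4-difluorophenyl also stays within the scatter (a 1.7-fold lower number from compound 1 to compound 4 (0.23 log units; within the scatter)). No available evidence bears on these results.

From the compounds shown here alone, whether a carboxylic acid or a morpholin-4-yl group on this carbonyl carbon would give a step beyond the scatter remains open.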